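Ethoxycarbonyl Amino to Ureido: A Small Step Expected

The source may report more compounds than this note shows. Statements on the series, on what has been measured and on what is new or still open speak of the compounds shown alone.

Three compounds share one core and differ only in the group on a single aromatic carbon. Compound 1 `CC(C)(C)c1nc(NC#N)ncc1-c1ccccc1` carries a cyanoamino group; in a functional assay on the whole organism for inhibition, with Rattus norvegicus as the target, with stated times of 1 h and 3.5 h, at a dose of 100 mg/kg by the oral route (a lower number here means less inhibition, a higher number more inhibition at the dose given (going by the name of the read-out)), compound 1 gives < 5%, which is a limit of the assay rather than a number. Compound 2 `CC(=O)N(C(C)=O)c1ncc(-c2ccccc2)c(C(C)(C)C)n1` bears a diacetylamino group, and in this assay compound 2 gives 22%. Compound 3 `CCOC(=O)Nc1ncc(-c2ccccc2)c(C(C)(C)C)n1` carries an (ethoxycarbonyl)amino group, and in this assay compound 3 gives 24%, the highest of the two numbers shown, with compound 2 nearest at a number 2 percentage points higher from compound 2 to compound 3 (within the scatter). The steps of a number at least 17 percentage points higher from compound 1 to compound 2 (beyond the scatter) and a number at least 19 percentage points higher from compound 1 to compound 3 (beyond the scatter) both lead away from the limit.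

Compound 4 `CC(C)(C)c1nc(NC(N)=O)ncc1-c1ccccc1` is not yet measured. It differs from compound 3 by amino in place of ethoxy on a carbonyl carbon. Going by the values given here, no measured step alters the carbonyl carbon itself; the closest comparison is a number 2 percentage points higher from compound 2 to compound 3 (within the scatter), where swapping diacetylamino for (ethoxycarbonyl)amino changed little. A step of similar small size, in no clear direction, is therefore expected in this assay, a number 2 percentage points lower from compound 3 to compound 4 (within the scatter). For compound 4 the estimated value is 22%, within 8% to 38%.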

Compound 4, a percentage reported as inhibition, in the whole organism at one dose (the size of the read-out at that dose, not a potency): 14%
For compound 4 the middle estimate is 8 percentage points above the measured one; low and high end bracket the measured number.
By their numbers in this assay, from the lowest: compounds 4, 2 and 3 (each within the scatter of the next). At a limit, below all of these: compound 1.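

Changing the carbonyl carbon itself, with amino in place of ethoxy, gives in this assay a number 10 percentage points lower from compound 3 to compound 4 (within the scatter) and so leaves ureido and (ethoxycarbonyl)amino not told apart. Ureido in place of diacetylamino reads the same way, with a number 8 percentage points lower from compound 2 to compound 4 (within the scatter) adding a third group on this aromatic carbon that cannot be separated from the others. Ureido does not stand clear of cyanoamino as the other two groups do, the step being a number at least 9 percentage points higher from compound 1 to compound 4 (that floor lies within the scatter) and that comparison starting from a limit: the limit of < 5% in this assay, at which 1 of the 4 values shown sits.

Going by these compounds, whether a plain amine on this aromatic carbon, or a longer chain such as butoxy on the carbonyl carbon, would move the number beyond the scatter stays open. A read-out at one dose also gives no potency for any of these compounds.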